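A few compounds are considered here, and "the series" means these few. Any claim that something is new, unique, unknown or untested is made for them only; others in the source may bear on it.

Measured in a functional assay for activation of Alpha-1D adrenergic receptor (Homo sapiens), read by calcium flux; on this read-out lower numbers stand for an effect already at smaller amounts and higher numbers for an effect only at larger amounts of compound:

compound 1 `c1csc(-c2ccccc2OCC2=NCCN2)c1` gives 15.9 nM
compound 2 `c1c[nH]c(-c2ccccc2OCC2=NCCN2)c1` gives 6.31 nM
compound 3 `Cc1csc(-c2ccccc2OCC2=NCCN2)n1` gives only a limit, < 100000 nM

Compound 1 holds the higher of the two numbers in this assay; its nearest neighbour is compound 2, reached by a 2.5-fold lower number from compound 1 to compound 2 (0.40 log units; beyond the scatter). For compound 3 the read-out is a limit and not a number (the limit of < 100000 nM in this assay, at which 1 of the 3 values shown sits). The steps a step that the limit leaves unreadable from compound 1 to compound 3 and a step that the limit leaves unreadable from compound 2 to compound 3 therefore cannot be sized.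

Compound 4 `Cn1nccc1-c1ccccc1OCC1=NCCN1` differs from compound 1 by 1-methyl-1H-pyrazol-5-yl in place of thiophen-2-yl on an aromatic carbon. Among the compounds with values here, two measured steps bear on it. Exchanging one five-membered ring with one hetero atom for another, from compound 1 to compound 2, gave a modest gain. Moving to a five-membered ring with two hetero atoms carrying a methyl, from compound 1 to compound 3, left the read-out at a limit. The 1-methyl-1H-pyrazol-5-yl group of compound 4 shares the second hetero atom and the methyl with compound 3, so a step toward a higher number is expected, of uncertain size, with a real chance of another limit. The expected step is a 9.4-fold higher number from compound 1 to compound 4 (0.97 log units; beyond the scatter). Compound 4 is therefore estimated at 150 nM in this assay, within 15 nM to 5000 nM.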

Compound 4, half-maximal effective concentration: < 100000 nM
Compound 4 ended at the assay's limit (the forecaster's own chance of this, stated with the estimate: 30%); the middle value lies beyond the limit too.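

In this assay compound 4 gives < 100000 nM, which is a limit and not a number, and the steps linking it to compound 1, compound 2 and compound 3 cannot be read. The compounds shown leave open whether any five-membered aromatic ring with 2 hetero atoms on the shared core gives a readable number in this assay.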